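The source may hold more compounds than are shown below. What is called first, only, known or untested is meant among the compounds shown, and "the series" means these compounds.

Values in a functional assay on HCT-116 cells (Homo sapiens) for cytotoxicity, read by sulforhodamine B assay, with a stated time of 48 h; on this read-out lower numbers stand for stronger inhibition and higher numbers for weaker inhibition:

Compound 1 `CCCCNC(=O)N1Cc2c(NC(=O)c3ccc(OC)cc3)nn(C(=O)C3CC3)c2C1`: 65500 nM
Compound 2 `O=C(Nc1nn(C(=O)C2CC2)c2c1CN(C(=O)c1ccccc1)C2)c1ccc(F)cc1`: 2280 nM

Compound 2, at 2280 nM, has the lower of the two numbers, and its gap to compound 1 lies beyond the usual scatter of repeated measurements. Compound 3 `COc1ccc(C(=O)Nc2nn(C(=O)C3CC3)c3c2CN(C(=O)c2ccccc2)C3)cc1` keeps the structure of compound 2 with one change: methoxy in place of fluoro on an aromatic carbon. This puts methoxy in place of fluoro on an aromatic carbon, turning 4-fluorophenyl into 4-methoxyphenyl. Among the measured compounds shown here, no measured pair isolates this change. Compound 1, at 65500 nM, also carries the 4-methoxyphenyl group, but it differs from compound 2 elsewhere too, so it offers only a weak hint toward higher numbers. The expected 1.8-fold higher number from compound 2 to compound 3 (0.24 log units; within the scatter) is therefore small, toward weaker inhibition, and may stay within the scatter. For compound 3 the estimated value is 4000 nM, with an expected range of 1300 nM to 15000 nM.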

Compound 3, half-maximal inhibitory concentration: 5180 nM
For compound 3 the middle estimate is 1.3-fold (0.11 log units) below the measured one, and the stated range covers the measured number.
By their numbers in this assay, from the lowest: compound 2; then compound 3; then compound 1.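

In this assay, the change from 4-fluorophenyl to 4-methoxyphenyl can now be read on its own: a 2.3-fold higher number from compound 2 to compound 3 (0.36 log units; beyond the scatter) is a modest weakening, so inhibition at this aromatic carbon largely survives the swap. With 4-methoxyphenyl held constant, phenyl in place of butylamino on a carbonyl carbon gives a 13-fold lower number from compound 1 to compound 3 (1.10 log units; beyond the scatter) as a large step, which shows that the poor value of compound 1 goes with its butylamino group and not with its methoxy. No measurement shown here explains either step.

On these data alone, it remains open how an amine, a nitrile or a plain hydrogen would read on the aromatic carbon. It is also unknown whether the butylamino step would keep its size alongside 4-fluorophenyl, or whether a longer chain would behave like butylamino.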